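The source may hold more compounds than are shown below. What is called first, only, known or untested is meant among the compounds shown, and "the series" means these compounds.

In an assay on HEK293 cells for positive allosteric modulation of metabotropic glutamate receptor 2 (Rattus norvegicus), read by thallium flux, with a stated time of 2.5 min (on this read-out lower numbers stand for smaller maximal responses and higher numbers for larger maximal responses), compound 3 `Cc1c(OCCCCOc2ccc(C(=O)O)cc2)ccc(C(=O)CC(C)C)c1O` gives 88%, the highest of the three numbers recorded. Compound 2 `Cc1c(OCCCCOc2ccc(C(=O)O)c(Cl)c2)ccc(C(=O)CC(C)C)c1O` gives 80.5%, and the step of a number 7.5 percentage points higher from compound 2 to compound 3 (within the scatter) lies within the scatter. Compound 1 `Cc1c(OCCCCOc2cccc(C(=O)O)c2)ccc(C(=O)CC(C)C)c1C` gives 12.1%, far below compound 3.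

Compound 4 `Cc1c(OCCCCOc2ccc(C(=O)O)cc2)ccc(C(=O)CC(C)C)c1C` differs from compound 3 in one place: methyl in place of hydroxy on an aromatic carbon. Within the data shown here, no measured step covers this exchange, so none bears directly on it; the only measured step, a number 7.5 percentage points higher from compound 2 to compound 3 (within the scatter), concerns a change in another part of the molecule. Compound 1 does carry the same methyl group as compound 4 on the shared core, and its number in this assay is far smaller than that of compound 3, but compound 1 and compound 4 also differ in another part of the molecule, so the two values of compound 1 and compound 3 can only be taken as a hint. Taken as such a hint, they point to a clear fall. A step beyond the scatter, downward, is therefore expected, a number 53 percentage points lower from compound 3 to compound 4 (beyond the scatter), with wide uncertainty. Compound 4 is estimated at 35%, with a range from 10% to 70%.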

Compound 4, largest response reached (reported as percent of maximum), in percent of the reference or control that the assay uses: 19%
Compound 4: middle estimate off by 16 percentage points, on the high side, and the stated range covers the measured number.
By their numbers in this assay, from the lowest: compounds 1 and 4 (each within the scatter of the next); then compounds 2 and 3 (each within the scatter of the next).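

In this assay, methyl in place of hydroxy on this aromatic carbon gives a number 69 percentage points lower from compound 3 to compound 4 (beyond the scatter), so this single exchange, with the rest of the molecule unchanged, is enough to separate a high maximal response from a low one. The carboxyphenyl exchange, 4-carboxyphenyl in place of 3-carboxyphenyl, gives a number 6.9 percentage points higher from compound 1 to compound 4 (within the scatter), so with methyl on the shared core the two carboxyphenyl groups cannot be told apart, and the low number of compound 1 goes with the methyl group rather than with the exchange between those two groups. Nothing measured here gives a reason for the large fall from hydroxy to methyl.

As far as these compounds go, it remains open whether a methoxy group, an amine or a fluoro group on this same aromatic carbon would give a number close to that of compound 3 or close to that of compound 4. From the compounds shown here alone, it is also open whether the 3-carboxyphenyl group, paired with hydroxy on the shared core, would give a high number as the 4-carboxyphenyl group does in compound 3.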